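This account rests on a few compounds, and the source may have more. Where it says the series, first, only, none or still open, it means among the compounds named here.

In a functional assay on MX1 cells (Homo sapiens) for antiproliferative activity, with a stated time of 72 h (a higher number here means that more compound is needed for the effect, a lower number that less compound is needed), compound 1 (`CCS(=O)(=O)Nc1ccc(Oc2ccc(C#N)cc2)c(-c2cn(C)c(=O)c3[nH]ccc23)c1`) gives 17 nM, compound 2 (`Cn1cc(-c2cc(NS(C)(=O)=O)ccc2Oc2ccccc2C(F)(F)F)c2cc[nH]c2c1=O`) gives 83 nM and compound 3 (`Cn1cc(-c2cc(NS(C)(=O)=O)ccc2Oc2ccc(F)cc2Cl)c2cc[nH]c2c1=O`) gives 27 nM. Compound 3 therefore lies within the scatter of compound 1 and clearly below compound 2.

Compound 4 (`Cn1cc(-c2cc(NS(C)(=O)=O)ccc2Oc2cccnc2)c2cc[nH]c2c1=O`) differs from compound 3 only in the group on an oxygen on an aromatic ring: pyridin-3-yl in place of 2-chloro-4-fluorophenyl on an oxygen on an aromatic ring. Pyridin-3-yl stands in place of 2-chloro-4-fluorophenyl.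

For the measured compounds named here, only one measured step concerns this place: a 3.1-fold lower number from compound 2 to compound 3 (0.49 log units; beyond the scatter), with 2-chloro-4-fluorophenyl in place of 2-(trifluoromethyl)phenyl. That step shows that exchanging this group can move the number by a modest amount. However, neither of its compounds carries a hetero atom in that ring, so the data offer no direct precedent for pyridin-3-yl. Compound 1 differs from compound 3 in more than one place and gives only a general reference.

Going by the values given here, a change of similar, modest size is therefore expected in this assay, towards a higher number, although this direction is a judgement that no measured step settles. The estimated step is a 2.2-fold higher number from compound 3 to compound 4 (0.35 log units; beyond the scatter). Compound 4 is expected at 60 nM, with an estimated range from 20 nM to 180 nM.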

Compound 4, half-maximal effective concentration: 34 nM
Compound 4: middle estimate off by 1.8-fold (0.25 log units), on the high side, and the stated range covers the measured number.
By their numbers in this assay, from the lowest: compounds 1, 3 and 4 (each within the scatter of the next); then compound 2.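

In this assay, for the compounds shown here, this is the first ring at this place to carry a hetero atom, and the exchange gives a 1.3-fold higher number from compound 3 to compound 4 (0.10 log units; within the scatter); pyridin-3-yl and 2-chloro-4-fluorophenyl therefore cannot be told apart here, although the entering group has no halogen, has fewer heavy atoms and adds a hydrogen-bond acceptor. Measured against the third group seen on this oxygen, pyridin-3-yl gives a 2.4-fold lower number from compound 2 to compound 4 (0.39 log units; beyond the scatter), so among the compounds that differ only here, compound 2 alone is separated from both others by steps beyond the scatter. Nothing available accounts for either step.

The compounds shown leave open whether pyridin-2-yl or pyridin-4-yl would read like pyridin-3-yl on this oxygen, and whether unsubstituted phenyl, with neither a halogen nor a ring nitrogen, would fall with compound 3 and compound 4 or with compound 2. They also leave open whether a saturated ring such as piperidin-4-yl, or a simple alkyl chain, would be tolerated at this place in place of an aromatic ring.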